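From propyl to allyl on an amine nitrogen

The source may hold more compounds than are shown below. What is called first, only, known or untested is meant among the compounds shown, and "the series" means these compounds.

Of the compounds shown here, three sharing one core have been measured in a physicochemical assay for lipophilicity, read by HPLC, using the shake flask method (a higher number here means a more lipophilic compound, a lower number a more polar compound), so far. Compound 1 (`CCCCCN(Cc1ccc(Cl)nc1)/C(C)=N/C#N`) carries pentyl on an amine nitrogen and gives 2.37 in this measurement. Compound 2 (`C/C(=N\C#N)N(Cc1ccc(Cl)nc1)C(C)C`) carries isopropyl there and gives 1.46 in the same measurement. Compound 3 (`CCCN(Cc1ccc(Cl)nc1)/C(C)=N/C#N`) carries propyl and gives 1.62 as its value, which stands within the scatter of compound 2 and well apart from compound 1.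

Compound 4 (`C=CCN(Cc1ccc(Cl)nc1)/C(C)=N/C#N`) differs from compound 3 by vinyl in place of ethyl on a saturated chain carbon bound to an amine nitrogen in one place: vinyl in place of ethyl on a saturated chain carbon bound to an amine nitrogen, which also reads as propyl to allyl.

The steps of a number 0.91 log units lower from compound 1 to compound 2 (beyond the scatter) and a number 0.75 log units lower from compound 1 to compound 3 (beyond the scatter) are modest and beyond the scatter, but both start from the pentyl of compound 1, a much larger change than this one. The closer guide is the step of a number 0.16 log units higher from compound 2 to compound 3 (within the scatter) and it stays within the scatter. For the measured compounds named here, no measured compound has a double bond in this chain, so the data hold no direct measure of that change. Only a small fall is expected, with a number 0.22 log units lower from compound 3 to compound 4 (within the scatter) as the estimated step and no move beyond the scatter. Compound 4 is estimated at 1.4 with an expected range from 1.1 to 1.7 in this measurement.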

Compound 4, partition coefficient: 1.56
Compound 4: the middle estimate sits 0.16 log units below what was measured, within the range that was stated.
By their numbers in this assay, from the lowest: compounds 2, 4 and 3 (each within the scatter of the next); then compound 1.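

In this assay, the double bond now has a direct measure: a number 0.06 log units lower from compound 3 to compound 4 (within the scatter) shows that vinyl in place of ethyl on a saturated chain carbon bound to an amine nitrogen leaves the reading within the scatter of the saturated chain. Allyl likewise cannot be told apart from isopropyl on the amine nitrogen, at a number 0.10 log units higher from compound 2 to compound 4 (within the scatter), so the propyl, isopropyl and allyl compounds form one cluster, while the pentyl of compound 1 stands clear of the newcomer, at a number 0.81 log units lower from compound 1 to compound 4 (beyond the scatter). Nothing measured here speaks to why these three chains read alike.

Still open, going by these compounds, is whether a double bond would count for as little on a longer chain, as a pentenyl group set against the pentyl of compound 1 would test, and at what chain length the reading leaves this cluster, which a butyl group on the amine nitrogen would help to place. On these data alone, it is also open whether a triple bond, as in propargyl, or a small ring, as in cyclopropylmethyl, would stay with these compounds.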